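A few compounds are considered here, and "the series" means these few. Any claim that something is new, unique, unknown or untested is made for them only; others in the source may bear on it.

Measured so far in a functional assay on ileum for inhibition of histamine H1 receptor (Cavia porcellus); a lower number here means a stronger inhibitor, a higher number a weaker inhibitor:
compound 1 `CCCCCCn1c(N2CCN(C)CC2)nc2ccccc21` gives 26 nM
compound 2 `CN1CCN(c2nc3ccccc3n2CCOCCO)CC1` gives 42 nM
compound 3 `CCCCOCCn1c(N2CCN(C)CC2)nc2ccccc21` gives 38 nM

All three share one core and differ only in the chain on the saturated carbon two bonds from the aromatic nitrogen. Compound 3 sits between the other two numbers, yet every gap is within the scatter: the step of a 1.5-fold higher number from compound 1 to compound 3 (0.16 log units; within the scatter) and the step of a 1.1-fold lower number from compound 2 to compound 3 (0.04 log units; within the scatter) are both too small to rank the compounds, and the step of a 1.6-fold higher number from compound 1 to compound 2 (0.21 log units; within the scatter) says the same.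

Compound 4 `CCSCCCn1c(N2CCN(C)CC2)nc2ccccc21` is the next variation at that same place. The change from compound 3 is (ethylsulfanyl)methyl in place of butoxy on a saturated chain carbon, two bonds along the chain from an aromatic nitrogen. Every measured step bears on this change, since each of them also swaps one chain for another at this position; none of them moved the number beyond the scatter, whether an oxygen was added to the chain, a hydroxy ended it, or an ethyl replaced the hydroxy. Going by the values given here, nothing among the measured compounds carries a sulfur, so the estimate rests on the observation that the chain has so far been tolerant of variation. The expected step is a 1.1-fold lower number from compound 3 to compound 4 (0.04 log units; within the scatter), that is, no movement beyond the scatter in this assay. For compound 4 the expected value is 35 nM, with a range from 15 nM to 90 nM.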

Compound 4, half-maximal inhibitory concentration: 530 nM
Compound 4: the middle estimate sits 15-fold (1.18 log units) below what was measured; the measured number lies above the stated range.
By their numbers in this assay, from the lowest: compounds 1, 3 and 2 (each within the scatter of the next); then compound 4.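

In this assay, going by these compounds alone, this position proves sensitive to the chain after all, with a 14-fold higher number from compound 3 to compound 4 (1.14 log units; beyond the scatter) as the first step here that lies beyond the scatter. The same holds against the hydroxy-ended chain, a 13-fold higher number from compound 2 to compound 4 (1.10 log units; beyond the scatter), and against the all-carbon chain, a 20-fold higher number from compound 1 to compound 4 (1.31 log units; beyond the scatter), so among these four compounds the sulfur-bearing chain of compound 4 stands apart from the all-carbon chain and both oxygen-bearing chains. The exchange of butoxy for (ethylsulfanyl)methyl leaves the hydrogen-bond donor and acceptor counts, the absence of a ring and the net charge unchanged, and no measurement at hand accounts for the large step.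

The change replaces oxygen with sulfur and also alters the chain, reading 2-butoxyethyl to 3-(ethylsulfanyl)propyl when cut one bond further out, so these compounds leave open whether the sulfur or its place along the chain matters. A 3-ethoxypropyl chain and a 2-(butylsulfanyl)ethyl chain would separate the two, while a chain ending in an amine or a carboxylic acid would test how far the position's sensitivity extends.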